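This account rests on a few compounds, and the source may have more. Where it says the series, first, only, none or still open, it means among the compounds named here.

Measured compounds:
Compound 1, `O=C1C=CC(=O)N1Cc1ccc(Oc2ccccc2)cc1`: in an assay on microsomes from brain (strain Sprague-Dawley) for inhibition of Fatty-acid amide hydrolase 1 (Rattus norvegicus), read by HPLC, with stated times of 10 min and 45 min (on this read-out higher numbers stand for weaker inhibition and lower numbers for stronger inhibition), compound 1 gives 4900 nM.
Compound 2, `CN(C)C(=O)n1nnnc1-c1ccc(Oc2ccccc2)cc1`: in this assay compound 2 gives 7 nM.
Compound 3, `CN(C)C(=O)n1nnc(-c2ccc(Oc3ccc(Cl)cc3)cc2)n1`: in this assay compound 3 gives 16 nM.

Compound 3 stands second highest of the three numbers. Its nearest neighbour is compound 2, whose number is lower by a step beyond the scatter, so compound 2 shows the stronger inhibition of the pair. Compound 1 sits furthest away, with a far higher number, again well beyond the scatter; compound 3 is thus far stronger than compound 1 but does not reach compound 2.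

Compound 4, `Cc1ccc(Oc2ccc(-c3nnn(C(=O)N(C)C)n3)cc2)cc1`, has not yet been measured in this assay. It differs from compound 3 in a single place: methyl in place of chloro on an aromatic carbon. For the measured compounds named here, no measured pair in this set shows the same exchange, so the direction has to be judged from the structural change alone. Exchanging one single heavy atom for another of the same size, with no change in donors, acceptors or charge, is expected to move the number little; the step from compound 3 is estimated to stay within the usual scatter, with no clear direction, so a 1.3-fold higher number from compound 3 to compound 4 (0.10 log units; within the scatter) is the expected step. For compound 4 the estimate is therefore 20 nM, with a range from 7 nM to 60 nM.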

Compound 4, half-maximal inhibitory concentration: 24 nM
For compound 4 the middle estimate is 1.2-fold (0.08 log units) below the measured one, within the range that was stated.
By their numbers in this assay, from the lowest: compound 2; then compounds 3 and 4 (each within the scatter of the next); then compound 1.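

In this assay, putting methyl in place of chloro on an aromatic carbon, para to a large group, gives a 1.5-fold higher number from compound 3 to compound 4 (0.18 log units; within the scatter), so the two groups cannot be told apart at this place. For the compounds shown here, this is the first pair in the set that differs in one place only, and it shows that going from 4-chlorophenoxy to 4-methylphenoxy leaves compound 4 level with compound 3 in this read-out. No measurement available here accounts for the two groups giving matching numbers.

The compounds shown leave open whether a methoxy group, a carboxylic acid, an amine or a plain hydrogen at this place would also stay level with chloro and methyl, or would part from them. Going by these compounds alone, they also leave open whether chloro and methyl would match on the core of compound 2, since the only exchange at this place so far sits on the core shared by compound 3 and compound 4.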